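This account rests on a few compounds, and the source may have more. Where it says the series, first, only, none or still open, it means among the compounds named here.

Compound 3, with the structure `Cc1n[nH]c(-c2ccccc2NCC2=NCCN2)n1`, stands apart from its two companions in this series. In an in vitro functional assay on cells (Fibroblast) for agonist activity at Alpha-1D adrenergic receptor (Homo sapiens) (on this read-out higher numbers stand for an effect only at larger amounts of compound and lower numbers for an effect already at smaller amounts), compound 3 gives < 5020 nM, and that figure is a limit of the assay rather than a number. Compound 1, `c1ccc(-c2nc[nH]n2)c(NCC2=NCCN2)c1`, gives 3.98 nM in this assay, while compound 2, `Cn1ncnc1-c1ccccc1NCC1=NCCN1`, gives 63.1 nM. For the measured compounds named here, the one readable step among the three is a 16-fold higher number from compound 1 to compound 2 (1.20 log units; beyond the scatter), and it comes from a 1-methyl-1H-1,2,4-triazol-5-yl in place of a 1H-1,2,4-triazol-3-yl on an aromatic carbon. The steps from compound 1 and from compound 2 to compound 3 cannot be sized, as the limit of < 5020 nM in this assay, at which 1 of the 3 values shown sits, shows.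

Compound 4, `Cc1nc(-c2ccccc2NCC2=NCCN2)n(C)n1`, has not yet been measured in this assay. It differs from compound 3 by methyl in place of hydrogen on an aromatic nitrogen. The step from compound 1 to compound 2 is the one that bears on this change, since it also places a methyl on a ring nitrogen of the triazole, and there the number rose sharply. The starting point, however, is only a limit, so the size of the step cannot be anchored. He therefore expects compound 4 to give roughly 3000 nM in this assay, within a range from 300 nM to 30000 nM, and he expects the change from compound 3 to be a step that the limit leaves unreadable from compound 3 to compound 4.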

Compound 4, half-maximal effective concentration: < 5020 nM
Compound 4: only a limit was reported; the forecaster's own chance of this, stated with the estimate: 40%; the middle value is on the limit's open side.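

Compound 4 gives < 5020 nM in this assay, and this too is a limit of the assay rather than a number. For the compounds shown here, no new step to compound 4 can be read from compound 2 or compound 3: the limit of < 5020 nM in this assay, at which 2 of the 4 values shown sit. The compounds shown leave open how far compound 3 and compound 4 actually lie from compound 1 and compound 2, and whether methyl in place of hydrogen on the aromatic nitrogen changes anything.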